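Fluoro to methoxy exchange in a cytotoxicity series

A few compounds are considered here, and "the series" means these few. Any claim that something is new, unique, unknown or untested is made for them only; others in the source may bear on it.

Measured so far:
compound 1 `COc1ccc2c(/C=C(\C#N)C(=O)c3c[nH]c4cc(F)ccc34)c[nH]c2c1` gives in a functional assay on MIA PaCa-2 cells (Homo sapiens) for cytotoxicity, read by WST assay, with a stated time of 24 h (a higher number here means a weaker inhibitor, a lower number a stronger inhibitor), only the limit > 50000 nM.
compound 2 `N#C/C(=C\c1c[nH]c2cc(F)ccc12)C(=O)c1c[nH]c2cc(F)ccc12` gives in this assay only the limit > 50000 nM.
compound 3 `N#C/C(=C\c1cn(Cc2ccc(Cl)cc2)c2ccccc12)C(=O)c1c[nH]c2cc(F)ccc12` gives in this assay only the limit > 50000 nM.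

None of these three values is a number; each is a limit of the assay, and the limit of > 50000 nM in this assay, at which 3 of the 3 values shown sit, covers all of them. From compound 2 to compound 1 the change is methoxy in place of fluoro on an aromatic carbon; the step that the two limits leave unreadable from compound 2 to compound 1 has no readable size because of the limit of > 50000 nM in this assay, at which 3 of the 3 values shown sit. How the core of compound 3 differs from that of compound 2 is not broken down here.

Compound 4 `COc1ccc2c(C(=O)/C(C#N)=C/c3cn(Cc4ccc(Cl)cc4)c4ccccc34)c[nH]c2c1` is not yet measured. It differs from compound 3 by methoxy in place of fluoro on an aromatic carbon, the same change as from compound 2 to compound 1, at a place described in the same words. That earlier step gives no size, so for compound 4 a value at or beyond the limit is expected, estimated as 80000 nM, between 25000 nM and 300000 nM. The expected step is a step that the limit leaves unreadable from compound 3 to compound 4, resting only on compound 3 remaining at > 50000 nM.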

Compound 4, half-maximal inhibitory concentration: > 50000 nM
Compound 4: only a limit was reported; the forecaster's own chance of this, stated with the estimate: 85%; the middle value is on the limit's open side.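

No new step can be read from compound 3 to compound 4, as both values are limits and not numbers: the limit of > 50000 nM in this assay, at which 4 of the 4 values shown sit. The compounds shown leave open whether methoxy in place of fluoro changes anything in this assay.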